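A few compounds are considered here, and "the series" means these few. Any claim that something is new, unique, unknown or untested is made for them only; others in the source may bear on it.

Compound 1 `NS(=O)(=O)c1ccc(C(=O)NNC(=O)c2ccccc2)cc1`, compound 2 `NS(=O)(=O)c1ccc(C(=O)NNC(=O)c2ccc(Cl)c(Cl)c2)cc1` and compound 3 `N#Cc1ccc(C(=O)NNC(=O)c2ccc(S(N)(=O)=O)cc2)cc1` share one core and differ only in the ring attached to one carbonyl. In an assay on cells for inhibition of Amine oxidase [flavin-containing] B (Homo sapiens), read by fluorescence and spectrophotometry, using microsomes, with a stated time of 20 min (a lower number here means a stronger inhibitor, a higher number a weaker inhibitor), compound 1 reaches only the limit of > 100000 nM. Compound 2 gives 10100 nM. Compound 3 gives 1170 nM, the lowest of the two numbers, its nearest neighbour being compound 2, with an 8.6-fold lower number from compound 2 to compound 3 (0.94 log units; beyond the scatter). Compound 4 `NS(=O)(=O)c1ccc(C(=O)NNC(=O)c2ccc(F)cc2)cc1` carries fluoro in place of cyano on an aromatic carbon. For the measured compounds named here, the steps that bear on this change are an at least 85-fold lower number from compound 1 to compound 3 (1.93 log units; beyond the scatter) and an 8.6-fold lower number from compound 2 to compound 3 (0.94 log units; beyond the scatter): cyano brought a large gain over hydrogen, and 3,4-dichlorophenyl a smaller one. A step back toward weaker inhibition is therefore expected, a 13-fold higher number from compound 3 to compound 4 (1.11 log units; beyond the scatter). Compound 4 is estimated at 15000 nM, within 3000 nM to 80000 nM.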

Compound 4, half-maximal inhibitory concentration: > 100000 nM
Compound 4: a limit, no number; the forecaster's own chance of this, stated with the estimate: 25%; at least 6.6-fold (0.82 log units) between middle value and limit.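

Replacing cyano with fluoro at this position does not keep the gain, giving an at least 85-fold higher number from compound 3 to compound 4 (1.93 log units; beyond the scatter). The 4-fluorophenyl ring also falls behind 3,4-dichlorophenyl, with an at least 9.9-fold higher number from compound 2 to compound 4 (0.99 log units; beyond the scatter), so among these compounds a single fluoro does not bring the gain seen with the other two rings. Compound 1 and compound 4 both stand at a limit, so the step between them cannot be read: the limit of > 100000 nM in this assay, at which 2 of the 4 values shown sit.

The compounds shown leave open whether the gain is particular to cyano. A carboxylic acid, an amine or a single chloro at this position would test that.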